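Trifluoromethyl in place of hydrogen on the phenyl of compound 3

This account rests on a few compounds, and the source may have more. Where it says the series, first, only, none or still open, it means among the compounds named here.

Compound 1 `CNc1nc(NCCCN(C)C)c2sc(-c3cccc(C#N)c3)cc2n1`: in a physicochemical assay for solubility, at pH 2 (on this read-out higher numbers stand for higher solubility and lower numbers for lower solubility), compound 1 gives > 100 ug/mL, which is a limit of the assay.
Compound 2 `CNc1nc(NCCCN(C)C)c2sc(-c3ccc(C(C)=O)cc3)cc2n1`: in this assay compound 2 gives > 100 ug/mL, again a limit.
Compound 3 `CNc1nc(NCCCN(C)C)c2sc(-c3ccccc3)cc2n1`: in this assay compound 3 gives > 100 ug/mL, also a limit.

Compound 3 therefore stands at the limit of this assay, and it does so together with every other measured value, as the limit of > 100 ug/mL in this assay, at which 3 of the 3 values shown sit, records. The measured steps give no readable size: a step that the two limits leave unreadable from compound 1 to compound 2, a step that the two limits leave unreadable from compound 1 to compound 3 and a step that the two limits leave unreadable from compound 2 to compound 3 are each enclosed by two limits, so they show only that the three phenyl substitutions tried so far leave the read-out at the limit.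

Compound 4 `CNc1nc(NCCCN(C)C)c2sc(-c3cccc(C(F)(F)F)c3)cc2n1` is the next compound. It differs from compound 3 by trifluoromethyl in place of hydrogen on an aromatic carbon. Of the measured steps, those from compound 3 to the other two measured compounds are the closest in kind, since each also exchanges a substituent on the same phenyl ring, and none of them moved the read-out off the limit. Going by the values given here, no measured step is readable, so no size of step can be derived from them. The expectation for compound 4 is accordingly that its value in this assay most probably again reaches the limit, with an estimated step that the limit leaves unreadable from compound 3 to compound 4. Compound 4 is estimated at 110 ug/mL, within a range from 35 ug/mL to 300 ug/mL.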

Compound 4, solubility: 180 ug/mL
Compound 4: the middle estimate sits 1.6-fold (0.21 log units) below what was measured, and the stated range covers the measured number.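

In this assay compound 3 gives > 100 ug/mL, which is a limit. Compound 4 gives 180 ug/mL, yet the steps to compound 4 from compound 1 and from compound 3 cannot be read. The compounds shown leave open how far any substituent on the phenyl ring moves the read-out in this assay.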